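The compounds below may be only part of what the source reports. "The series", "measured", "known", "first", "only" and "open" are said of these compounds alone.

Measured so far in a functional assay on the whole organism (Tail, strain ICR) with Mus musculus as the target, in the tail flick test, with a stated time of 120 min, at a dose of 25 umol/kg by the oral route; a higher number here means a stronger effect of the compound at the dose given, a lower number a weaker effect:

compound 1 `O=C(O)[C@@H]1CCCN1C(=O)CN(c1nc(Cl)nc2[nH]cnc12)C1CC1` — 23.6%
compound 2 `CSCC[C@H](NC(=O)CN(c1nc(Cl)nc2[nH]cnc12)C1CC1)C(=O)OCc1ccccc1` — 31.6%
compound 3 `O=C(OCc1ccccc1)[C@@H]1CCCN1C(=O)CN(c1nc(Cl)nc2[nH]cnc12)C1CC1` — 38.4%

Compound 1 gives the lowest of the three numbers. Against compound 2 the gap is within the scatter, so no order between those two is claimed; against compound 3 the gap is beyond the scatter: a number 14.8 percentage points higher from compound 1 to compound 3 (beyond the scatter), with benzyl in place of hydrogen on an oxygen next to a carbonyl group.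

Compound 4 `C[C@@H](O)[C@H](NC(=O)CN(c1nc(Cl)nc2[nH]cnc12)C1CC1)C(=O)O` is not yet measured. It differs from compound 1 as follows: (1-carboxy-2-hydroxypropyl)amino in place of 2-carboxypyrrolidin-1-yl on a carbonyl carbon. The free carboxylic acid is kept; what changes is the ring opened to a chain bearing a hydroxyl.

Within the data shown here, no measured step covers this change directly. Among the measured compounds shown here, the one measured step, from compound 1 to compound 3, concerns the ester and not the amino-acid part. Compound 2 and compound 3 show what a chain amino acid and the pyrrolidine acid give as benzyl esters: their two values lie within the scatter of each other. On that basis the amino-acid part appears to matter little, and for compound 4 the expected change in this assay from compound 1 is a number 1.6 percentage points lower from compound 1 to compound 4 (within the scatter), not beyond the scatter. Compound 4 is therefore estimated at 22%, with a range from 8% to 38%.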

Compound 4, a percentage reported as activity, at one dose (the size of the read-out at that dose, not a potency): 37.6%
Beside the measured number, compound 4's estimate is 15.6 percentage points below it; measured number inside the range.
By their numbers in this assay, from the lowest: compounds 1, 2, 4 and 3 (each within the scatter of the next, the first and the last beyond it).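

In this assay, the place on the carbonyl carbon matters with the free carboxylic acid kept: a number 14 percentage points higher from compound 1 to compound 4 (beyond the scatter), with (1-carboxy-2-hydroxypropyl)amino in place of 2-carboxypyrrolidin-1-yl. Among the benzyl esters, the earlier pair, compound 2 and compound 3, had shown only a gap within the scatter for a change at this place, so that pair does not carry over to the free acids. No available data bear on the reason for this step.

The compounds shown cannot separate the opening of the ring from the hydroxyl, and a free acid with a plain isopropyl chain would be the one to set against compound 4. Also open, as far as these compounds go, is what a benzyl ester on compound 4 would give.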